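Chloro in place of fluoro: from compound 3 to compound 4

The compounds below may be only part of what the source reports. "The series", "measured", "known", "first", "only" and "open" are said of these compounds alone.

Measured compounds:
compound 1, `CS(=O)(=O)c1ccc(Cc2n[nH]c(=S)n2/N=C/c2ccc(F)cc2)cc1`, gives 57.8% in a functional assay on HeLa cells (Homo sapiens) for cytotoxicity, read by MTT assay, with a stated time of 48 h, tested at 100 uM; a higher number here means a stronger effect of the compound at the concentration tested, a lower number a weaker effect
compound 2, `CS(=O)(=O)c1ccc(Cc2n[nH]c(=S)n2/N=C/c2ccc(Cl)cc2)cc1`, gives 57%
compound 3, `CS(=O)(=O)c1ccc(Cc2n[nH]c(=S)n2/N=C/c2ccccc2F)cc1`, gives 28.1%

Compound 3 stands lowest of the three numbers in this assay; the steps to it are a number 29.7 percentage points lower from compound 1 to compound 3 (beyond the scatter) and a number 28.9 percentage points lower from compound 2 to compound 3 (beyond the scatter), both beyond the scatter. Compound 4, `CS(=O)(=O)c1ccc(Cc2n[nH]c(=S)n2/N=C/c2ccccc2Cl)cc1`, differs from compound 3 in one place: chloro in place of fluoro on an aromatic carbon. Among the compounds with values here, the only measured step of the same kind is a number 0.8 percentage points lower from compound 1 to compound 2 (within the scatter), which lies within the scatter. On that basis no step beyond the scatter is expected here: the estimate is a number 0.1 percentage points lower from compound 3 to compound 4 (within the scatter). Compound 4 is therefore expected to give about 28% in this assay, with a range from 14% to 42%.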

Compound 4, a percentage reported as activity, at one concentration (the size of the read-out at that concentration, not a potency): 76.5%
Compound 4: the middle estimate sits 48.5 percentage points below what was measured, and the stated range ends below it.
By their numbers in this assay, from the lowest: compound 3; then compounds 2 and 1 (each within the scatter of the next); then compound 4.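

Chloro in place of fluoro on an aromatic carbon ortho to a large group has an effect that the same change on the 4-fluorophenyl compound did not show: the same change on two cores in this assay, a number 0.8 percentage points lower (within the scatter) from compound 1 to compound 2 and a number 48.4 percentage points higher (beyond the scatter) from compound 3 to compound 4, 49.2 percentage points apart, beyond the scatter of two such steps. The step of a number 48.4 percentage points higher from compound 3 to compound 4 (beyond the scatter) also means that the 2-substituted phenyl does not by itself lower the number. With 2-chlorophenyl the comparisons with the 4-substituted compounds reverse direction, giving a number 19.5 percentage points higher from compound 2 to compound 4 (beyond the scatter) and a number 18.7 percentage points higher from compound 1 to compound 4 (beyond the scatter).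

As far as these compounds go, whether this rise extends beyond chloro, for example to bromo, methyl or methoxy on the same carbon, stays open. A single tested concentration also leaves potency open.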